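The source may hold more compounds than are shown below. What is called first, only, known or untested is meant among the compounds shown, and "the series" means these compounds.

Measured compounds:
Compound 1 `O=C(O)CCc1nnc(C(=O)Nc2cccc(-c3ccc(F)cc3)c2)s1`: > 4 h (a limit of the assay)
Compound 2 `O=C(O)CCc1ccc(OCc2nnc(C(=O)Nc3ccccc3F)s2)cc1`: 0.34 h

Within the data shown here, in an ADME assay on the whole organism (plasma) for metabolic stability, with Mus musculus as the target, read by LC-MS, tested at 1 uM (on this read-out lower numbers stand for a shorter-lived compound and higher numbers for a longer-lived compound), compound 2 gives 0.34 h, and this is the only true number available so far. Compound 1 reads > 4 h, which is a limit of the assay and not a number. Compound 2 therefore has no second number to be ranked against.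

Compound 3 `O=C(O)CCc1ccc(OCc2nnc(C(=O)Nc3cccc(Cl)c3)s2)cc1` has not yet been measured. It differs from compound 2 in one place: 3-chlorophenyl in place of 2-fluorophenyl on an amide-type nitrogen. In words, 3-chlorophenyl stands in place of 2-fluorophenyl on an amide-type nitrogen, and the rest of the structure is unchanged.

Among the measured compounds shown here, no two measured compounds differ in only one place, so the data give no direct size for a change of this kind. The best anchor is compound 2 at 0.34 h, the closest measured structure. The expected step of a 1.2-fold higher number from compound 2 to compound 3 (0.07 log units; within the scatter) is none beyond the usual scatter of repeated measurements, and neither direction is favoured. For compound 3 the expected half-life is 0.4 h, with an estimated range of 0.15 h to 1.2 h.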

Compound 3, half-life in the Mus musculus assay: 1.93 h
Beside the measured number, compound 3's estimate is 4.8-fold (0.68 log units) below it; measured number outside the range, above it.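

In the Mus musculus assay, 3-chlorophenyl in place of 2-fluorophenyl on an amide-type nitrogen gives a 5.7-fold higher number from compound 2 to compound 3 (0.75 log units; beyond the scatter), the first size available for any single change among these compounds, and it shows that the half-life responds to the group at this position. In a physicochemical assay for lipophilicity, read by LC-MS, at pH 7.4 (a lower number here means a more polar compound, a higher number a more lipophilic compound), compound 2 gives 0.95 and compound 3 gives 1.46. Among these compounds, the same change also gives a more lipophilic compound, a shift measured for this pair: the measured distribution coefficient of compound 2, 0.95, and of compound 3, 1.46, a number 0.51 log units higher (beyond the scatter) With only this one pair, the data do not tell whether the longer half-life and the higher distribution coefficient are linked.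

The compounds shown leave open whether the step in half-life belongs to the chlorine or to where it sits on the ring, and how an unsubstituted phenyl or a phenyl carrying a nitrile would read in place of either group. In the Mus musculus assay compound 1 reads > 4 h, which is a limit of the assay and not a number, and it differs from the other compounds in more than one place, so it gives no size for any change.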